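Methyl on the Amine: What Compound 3 Should Show

This account rests on a few compounds, and the source may have more. Where it says the series, first, only, none or still open, it means among the compounds named here.

compound 1 `COc1c(N2CC[C@@H](CN)C2)c(F)cc2c(=O)c(C(=O)O)cn(Cc3ccc(-c4ccccc4)cc3)c12`: 26000 nM in an assay on isolated protein for inhibition of DNA topoisomerase 1 (Homo sapiens), with a stated time of 15 min; on this read-out higher numbers stand for weaker inhibition and lower numbers for stronger inhibition
compound 2 `COc1c(N2CC[C@@H](CN)C2)c(F)cc2c(=O)c(C(=O)O)cn(Cc3ccc(-n4cccn4)cc3)c12`: > 200000 nM, which is a limit of this assay and not a number

Going by the values given here, compound 1 gives the only number in this assay. Among the compounds with values here, the single measured step leading away from it, an at least 7.6-fold higher number from compound 1 to compound 2 (0.88 log units; beyond the scatter), ends at the limit of > 200000 nM in this assay, at which 1 of the 2 values shown sits. Compound 3 `CNC[C@@H]1CCN(c2c(F)cc3c(=O)c(C(=O)O)cn(Cc4ccc(-c5ccccc5)cc4)c3c2OC)C1` differs from compound 1 by methyl in place of hydrogen on an amine nitrogen. The measured step alters another part of the shared core and does not bear on this change, so no step beyond the scatter is expected: no change at the digits printed from compound 1 to compound 3 (within the scatter). Compound 3 is therefore estimated at 26000 nM, between 8000 nM and 90000 nM.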

Compound 3, half-maximal inhibitory concentration: 155000 nM
Beside the measured number, compound 3's estimate is 6.0-fold (0.78 log units) below it; the whole stated range lies below it.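

In this assay, methyl in place of hydrogen on an amine nitrogen gives a 6.0-fold higher number from compound 1 to compound 3 (0.78 log units; beyond the scatter). The read-out therefore responds to the aminomethyl group as well as to the phenyl group replaced in compound 2, and a single added carbon is enough to move it. Compound 2 remains at a limit and not a number: the limit of > 200000 nM in this assay, at which 1 of the 3 values shown sits.

The compounds shown leave open how a second methyl, an ethyl or an acetyl group on the same nitrogen would read. They also leave open why this methyl raises the number.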